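The source may hold more compounds than are shown below. What is called first, only, known or untested is meant among the compounds shown, and "the series" means these compounds.

Three compounds have been measured in a functional assay for antagonist activity at transient receptor potential cation channel subfamily V member 1 (Homo sapiens), read by FLIPR; on this read-out lower numbers stand for stronger inhibition and higher numbers for weaker inhibition:

Compound 1 `Cc1cccnc1-c1ccc(C(=O)Nc2ccc(C(C)(C)C)cc2)cc1`: 11 nM
Compound 2 `CC(C)(C)c1ccc(NC(=O)c2ccc(-c3ccccn3)cc2)cc1`: 11 nM
Compound 3 `CCS(=O)(=O)Nc1cccnc1-c1ccc(C(=O)Nc2ccc(C(C)(C)C)cc2)cc1`: 49 nM

Compound 3 gives the highest number of the three. The step of no change at the digits printed from compound 1 to compound 2 (within the scatter) shows that the methyl contributes nothing measurable, whereas a 4.5-fold higher number from compound 1 to compound 3 (0.65 log units; beyond the scatter) and a 4.5-fold higher number from compound 2 to compound 3 (0.65 log units; beyond the scatter) show that the (ethylsulfonyl)amino group costs a modest amount of potency in this assay. Compound 4 `CC(C)(C)c1ccc(NC(=O)c2ccc(-c3ncccc3N(S(C)(=O)=O)S(C)(=O)=O)cc2)cc1` carries bis(methylsulfonyl)amino in place of (ethylsulfonyl)amino on an aromatic carbon. Among the measured compounds shown here, no measured step covers a second sulfonyl group or the loss of the donor, so the direction rests on the single precedent that the first sulfonyl group weakened inhibition. Compound 4 is therefore expected to give 100 nM in this assay, in the range 30 nM to 400 nM, which amounts to an expected step of a 2.0-fold higher number from compound 3 to compound 4 (0.31 log units; beyond the scatter).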

Compound 4, half-maximal inhibitory concentration in the transient receptor potential cation channel subfamily V member 1 assay: 0.8 nM
The estimate for compound 4 lay 130-fold (2.10 log units) above the measured number; measured number below the stated range.
By their numbers in the transient receptor potential cation channel subfamily V member 1 assay, from the lowest: compound 4; then compounds 1 and 2 (each within the scatter of the next); then compound 3.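

In the transient receptor potential cation channel subfamily V member 1 assay compound 4 gives 0.8 nM, and bis(methylsulfonyl)amino in place of (ethylsulfonyl)amino gives a 61-fold lower number from compound 3 to compound 4 (1.79 log units; beyond the scatter), so this position, where the first sulfonyl group had cost potency, can also carry a group that outdoes both smaller substituents, with a 14-fold lower number from compound 2 to compound 4 (1.14 log units; beyond the scatter) and a 14-fold lower number from compound 1 to compound 4 (1.14 log units; beyond the scatter). In a physicochemical assay for solubility, at pH 7.4 (a lower number here means a less soluble compound, a higher number a more soluble compound), compound 3 gives 1 ug/mL and compound 4 gives 1 ug/mL. In the physicochemical assay the same change gives no change at the digits printed from compound 3 to compound 4 (within the scatter). Nothing available here accounts for the gain. The compounds shown leave open whether the gain needs the second sulfonyl group at all, which a methyl(methylsulfonyl)amino group would separate from the loss of the hydrogen-bond donor.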